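The compounds below may be only part of what the source reports. "The series", "measured", "known", "first", "only" and "open" are said of these compounds alone.

Compound 1 `Clc1cccc2c(Cc3cc4ccccc4[nH]3)c[nH]c12` gives 2800 nM in an assay on HepG2 cells for inhibition of Proprotein convertase subtilisin/kexin type 9 (Homo sapiens), read by AlphaLISA, with a stated time of 48 h (on this read-out lower numbers stand for stronger inhibition and higher numbers for weaker inhibition), the higher of the two numbers measured. Compound 2 `Fc1cccc2c(Cc3cc4ccccc4[nH]3)c[nH]c12` gives 300 nM in this assay. Among the compounds with values here, the only measured step, a 9.3-fold lower number from compound 1 to compound 2 (0.97 log units; beyond the scatter), comes from fluoro in place of chloro on an aromatic carbon. Compound 3 `Fc1ccc2[nH]c(Cc3c[nH]c4c(Cl)cccc34)cc2c1` keeps the chloro of compound 1 and differs by fluoro in place of hydrogen on an aromatic carbon. Within the data shown here, no measured step touches this ring, so the change from compound 1 to compound 3 in this assay is expected to be a 1.4-fold lower number from compound 1 to compound 3 (0.15 log units; within the scatter), at most modest and possibly within the scatter. Compound 3 is estimated at 2000 nM, within 700 nM to 6000 nM.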

Compound 3, half-maximal inhibitory concentration: 250 nM
Compound 3: the middle estimate sits 8.0-fold (0.90 log units) above what was measured, outside the stated range (below it).
By their numbers in this assay, from the lowest: compounds 3 and 2 (each within the scatter of the next); then compound 1.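

With the chloro kept, fluoro in place of hydrogen on this six-membered aromatic ring of carbon only gives an 11-fold lower number from compound 1 to compound 3 (1.05 log units; beyond the scatter) in this assay, a large step. Within the data shown here, this position, which no earlier step touched, therefore responds to a single fluoro, and the chloro of compound 1 does not by itself keep the number high. No evidence on hand accounts for this step. The compounds shown leave open whether chloro, methoxy or an amine at this position would also lower the number, and whether this fluoro adds to the change from chloro to fluoro when both stand in one compound.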